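A Trifluoromethyl Ketone Replaces the Fluorophenyl Arm

The source may report more compounds than this note shows. Statements on the series, on what has been measured and on what is new or still open speak of the compounds shown alone.

Three compounds share one core, and their numbers come from an assay (Rattus norvegicus) for inhibition of Fatty-acid amide hydrolase 1 (Homo sapiens); a higher number here means a weaker inhibitor, a lower number a stronger inhibitor. Compound 2 `O=C(CCCCCCc1ccccc1)c1ncc(-c2ccc(F)cc2)o1` gives 62 nM, the lowest of the three. Compound 3 `O=C(CCCCCCc1ccccc1)c1ncc(-c2cnc(C(=O)CCCCCCc3ccccc3)o2)o1`, in which a second copy of the core replaces the fluorophenyl arm, gives 3500 nM, a gap to compound 2 that lies beyond the scatter. Compound 1 `O=C(CCCCCCc1ccccc1)c1ncc(-c2ccccc2C(=O)C(F)(F)F)o1`, where a (trifluoromethyl)carbonyl hangs on the phenyl ring, gives 5000 nM, further still from compound 2. So compound 2 stands clearly apart from the other two as the strongest inhibitor.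

The step to be followed goes from compound 2 to compound 4 `O=C(CCCCCCc1ccccc1)c1ncc(C(=O)C(F)(F)F)o1`: (trifluoromethyl)carbonyl in place of 4-fluorophenyl on an aromatic carbon. The change sits on an aromatic carbon of the five-membered aromatic ring with one nitrogen and one oxygen, next to the ring oxygen. The ring that leaves is the same one that, in compound 1, carried the (trifluoromethyl)carbonyl; in compound 4 that group attaches directly to the core instead.

For the measured compounds named here, no measured pair shows this exact change, so the size of the step rests on expectation alone. Compound 4 is expected to be a weaker inhibitor than compound 2, with the loss moderate rather than severe, a 4.0-fold higher number from compound 2 to compound 4 (0.61 log units; beyond the scatter). For compound 4 the estimated value in this assay is 250 nM, within 40 nM to 1500 nM.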

Compound 4, inhibition constant: 4 nM
Compound 4: middle estimate off by 63-fold (1.80 log units), on the high side, and the stated range ends above it.
By their numbers in this assay, from the lowest: compound 4; then compound 2; then compounds 3 and 1 (each within the scatter of the next).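

Placing (trifluoromethyl)carbonyl on this aromatic carbon instead of 4-fluorophenyl gives a 16-fold lower number from compound 2 to compound 4 (1.19 log units; beyond the scatter) in this assay, so a ring is not needed here for strong inhibition, and a group with no ring can do far better than one with a ring. The earlier compounds shown here all carried a ring at this place, and the (trifluoromethyl)carbonyl appeared only on a phenyl ring, where compound 1 gives 5000 nM and stands among the highest numbers; attached directly to the core, the same group gives compound 4 the lowest number of the four. Nothing given here explains why this change has such a large effect.

The compounds shown leave open whether the carbonyl, the trifluoromethyl or the two together account for the gain, a question that a methyl ketone, a carboxylic acid or a nitrile on this same carbon could help to answer. They also leave open whether the gain would hold with a shorter chain on the other side of the core.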